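A few compounds are considered here, and "the series" means these few. Any claim that something is new, unique, unknown or untested is made for them only; others in the source may bear on it.

Measured in a functional assay on DU-145 cells (Homo sapiens) for antiproliferative activity, read by sulforhodamine B assay, with a stated time of 48 h; a higher number here means a weaker inhibitor, a lower number a stronger inhibitor:

- compound 1 `Cc1cccc(NS(=O)(=O)c2ccc(N3CCNC3=O)cc2)c1`: 580 nM
- compound 2 `CCc1cccc(NS(=O)(=O)c2ccc(N3CCNC3=O)cc2)c1`: 730 nM
- compound 3 `Cc1ccc(C)c(NS(=O)(=O)c2ccc(N3CCNC3=O)cc2)c1`: 1610 nM

In this assay, compound 3 at 1610 nM has the highest number of the three and is the weakest inhibitor of the set. The next compound, compound 4 `COc1cccc(NS(=O)(=O)c2ccc(N3CCNC3=O)cc2)c1`, keeps the shared core and has 3-methoxyphenyl in place of 2,5-dimethylphenyl on a sulfonamide nitrogen, a change counted as 3-methoxyphenyl in place of 2,5-dimethylphenyl on a sulfonamide nitrogen.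

The change removes the group that sets compound 3 apart from compound 1 and compound 2, so the steps that separate them bear most directly on it. These are a 2.8-fold higher number from compound 1 to compound 3 (0.44 log units; beyond the scatter) and a 2.2-fold higher number from compound 2 to compound 3 (0.34 log units; beyond the scatter), both modest. The remaining measured step is a 1.3-fold higher number from compound 1 to compound 2 (0.10 log units; within the scatter), so those two compounds form a single level for this comparison. Going by the values given here, no measured compound carries a methoxy group, which leaves the range wide.

A modest fall in the number is therefore expected, towards the level of compound 1 and compound 2. The expected change is a 2.3-fold lower number from compound 3 to compound 4 (0.36 log units; beyond the scatter). For compound 4 the estimated value is 700 nM, with an expected range from 300 nM to 1600 nM.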

Compound 4, half-maximal inhibitory concentration: 650 nM
The estimate for compound 4 lay 1.1-fold (0.03 log units) above the measured number; the range from low to high includes it.
By their numbers in this assay, from the lowest: compounds 1, 4 and 2 (each within the scatter of the next); then compound 3.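

In this assay, replacing 2,5-dimethylphenyl with 3-methoxyphenyl on the sulfonamide nitrogen gives a 2.5-fold lower number from compound 3 to compound 4 (0.39 log units; beyond the scatter), which places compound 4 at the level of compound 1 and compound 2 rather than that of compound 3. Methoxy in place of methyl gives a 1.1-fold higher number from compound 1 to compound 4 (0.05 log units; within the scatter) and methoxy in place of ethyl gives a 1.1-fold lower number from compound 2 to compound 4 (0.05 log units; within the scatter), so this assay does not tell these three groups apart on that aromatic carbon, even though methoxy brings an oxygen and a hydrogen-bond acceptor that the two carbon groups lack. No measurement shown here offers a reason for this level or for the separate standing of compound 3.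

Compound 3 is the only compound with 2,5-dimethylphenyl, so the compounds shown do not settle which of its two methyl groups goes with its separate level, or whether both are needed. Going by these compounds, how an amine, a carboxylic acid or a longer alkoxy chain on that aromatic carbon would read in this assay also remains open, so the flat level seen with methyl, ethyl and methoxy may not extend beyond these three groups.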